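Esters of the shared core: a change on the carbonyl carbon

The source may hold more compounds than are shown below. What is called first, only, known or untested is meant among the compounds shown, and "the series" means these compounds.

Measured compounds:
- compound 1, `O=C(OC1CCC(CN2CCN(c3cc(=O)c4cc(C(F)(F)F)cc([N+](=O)[O-])c4s3)CC2)CC1)c1ccco1`: 0.075 h
- compound 2, `CC(=O)NC1CCC(CN2CCN(c3cc(=O)c4cc(C(F)(F)F)cc([N+](=O)[O-])c4s3)CC2)CC1`: > 1.55 h
- compound 3, `O=C(OC1CCC(CN2CCN(c3cc(=O)c4cc(C(F)(F)F)cc([N+](=O)[O-])c4s3)CC2)CC1)c1cccs1`: 0.0917 h

In an ADME assay on cells (Hepatocyte, Homo sapiens) for metabolic stability (on this read-out higher numbers stand for a longer-lived compound and lower numbers for a shorter-lived compound), compound 3 gives 0.0917 h, the higher of the two plain numbers. Its nearest neighbour is compound 1, which gives 0.075 h, and the two sit within the scatter of each other: a 1.2-fold higher number from compound 1 to compound 3 (0.09 log units; within the scatter). For compound 2 this assay reports only a limit, > 1.55 h, not a number. The step from compound 3 to compound 2 is nonetheless large, an at least 16-fold lower number from compound 2 to compound 3 (1.22 log units; beyond the scatter) read in reverse, and it rests on (the limit of > 1.55 h in this assay, at which 1 of the 3 values shown sits).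

Compound 4, `COc1ccc(C(=O)OC2CCC(CN3CCN(c4cc(=O)c5cc(C(F)(F)F)cc([N+](=O)[O-])c5s4)CC3)CC2)cc1`, has not yet been measured. It differs from compound 3 in one place: 4-methoxyphenyl in place of thiophen-2-yl on a carbonyl carbon. This is again a swap of the aromatic group on the carbonyl carbon, while the ester link to the saturated ring stays. Within the data shown here, the only measured step of that kind, a 1.2-fold higher number from compound 1 to compound 3 (0.09 log units; within the scatter), stayed within the scatter. The large step, an at least 20-fold higher number from compound 1 to compound 2 (1.31 log units; beyond the scatter), changed the ester link itself, which compound 4 keeps. The step to compound 4 is therefore expected to stay within the scatter: a 1.2-fold higher number from compound 3 to compound 4 (0.08 log units; within the scatter) is the estimated step. Compound 4 is estimated to give 0.11 h in this assay, between 0.04 h and 0.3 h.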

Compound 4, half-life: 0.165 h
The estimate for compound 4 lay 1.5-fold (0.18 log units) below the measured number; low and high end bracket the measured number.
By their numbers in this assay, from the lowest: compounds 1, 3 and 4 (each within the scatter of the next, the first and the last beyond it). At a limit, above all of these: compound 2.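

Within the ester series, this assay shows that a six-membered aromatic ring can take the place of a five-membered one on the carbonyl carbon without a change beyond the scatter: a 1.8-fold higher number from compound 3 to compound 4 (0.26 log units; within the scatter). Among these compounds, compound 4 also gives the first step between two aromatic esters that passes beyond the scatter, a 2.2-fold higher number from compound 1 to compound 4 (0.34 log units; beyond the scatter), so the group on this carbonyl carbon can shift the half-life modestly, although the step from compound 1 to compound 3 did not. Even with 4-methoxyphenyl in place, the ester stays well apart from the acetamido compound, an at least 9.3-fold lower number from compound 2 to compound 4 (0.97 log units; beyond the scatter), and that step is read against a limit of the assay, not a plain number: the limit of > 1.55 h in this assay, at which 1 of the 4 values shown sits.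

This swap changes the ring and brings in the methoxy group at once, so a plain phenyl ring on the same carbonyl carbon would be needed to tell those two parts apart. On these data alone, it also remains open how an amide carrying 4-methoxyphenyl, with a nitrogen in place of the ester oxygen, would behave, and whether the aromatic group still matters once the ester link is gone.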